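One Methyl Group, Two Fused Rings, and Liver Stability

This account rests on a few compounds, and the source may have more. Where it says the series, first, only, none or still open, it means among the compounds named here.

Compound 1 `CNc1cc(C)c(C(N)=O)cn1` and compound 2 `NC(=O)c1cnc2c(c1)CCN2` have both been tested in an ADME assay on microsomes from liver (Mus musculus) for metabolic stability, read by LC-MS, with a stated time of 60 min; a higher number here means that more of the compound is left, a lower number that less of the compound is left. Compound 1 gives 85%. Compound 2 gives 89%, and its distance from compound 1 lies within the scatter, so the two compounds read as alike. Compound 3 `C[C@@H]1Cc2cc(C(N)=O)cnc2N1` has not yet been measured. Compared with compound 2 it carries methyl in place of hydrogen on a saturated ring carbon. Going by the values given here, no measured pair shows what such a change does here. In this assay only a small shift is expected, a number 4 percentage points lower from compound 2 to compound 3 (within the scatter), not beyond the scatter in either direction. Compound 3 is therefore estimated at 85%, within a range from 72% to 95%.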

Compound 3, percent of the compound remaining: 93%
For compound 3 the middle estimate is 8 percentage points below the measured one, within the range that was stated.
By their numbers in this assay, from the lowest: compounds 1, 2 and 3 (each within the scatter of the next).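

In this assay, methyl in place of hydrogen on a saturated ring carbon, next to the ring nitrogen, gives a number 4 percentage points higher from compound 2 to compound 3 (within the scatter) and so leaves the read-out within the scatter. Going by these compounds alone, this is the first measured pair to show that this ring carbon can carry a methyl without a shift beyond the scatter. Nothing measured on these compounds explains the result. Going by these compounds, whether an ethyl chain, an amine or a carboxylic acid on the same ring carbon would read alike stays open. So does the effect of the methyl in its mirror-image arrangement.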